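A few compounds are considered here, and "the series" means these few. Any claim that something is new, unique, unknown or untested is made for them only; others in the source may bear on it.

In a functional assay on DLD-1 cells (Homo sapiens) for antiproliferative activity, read by CellTiter-Glo, with a stated time of 72 h (on this read-out lower numbers stand for stronger inhibition and higher numbers for weaker inhibition), three compounds have been measured:

Compound 1 `CC1CCN(C2CCN(S(=O)(=O)c3ccc(F)cc3F)CC2)CC1`: 102 nM
Compound 2 `CC1CCN(C2CCN(C(=O)c3ccc(OC(F)(F)F)cc3)CC2)CC1`: 426 nM
Compound 3 `Cc1cc(C)c(S(=O)(=O)N2CCC(N3CCC(c4ccccc4)CC3)CC2)c(C)c1`: 865 nM

Compound 3 stands at the highest of the three numbers, that is, the weakest inhibition; compound 2 is nearest to it and compound 1 furthest from it, and both gaps lie beyond the usual scatter. Compound 4 `Cc1cc(C)c(S(=O)(=O)N2CCC(N3CCC(Cc4ccccc4F)CC3)CC2)c(C)c1` shares the core of compound 3 and differs from it in a single place: 2-fluorobenzyl in place of phenyl on a saturated ring carbon. Among the measured compounds shown here, no measured pair in this set traces a comparable change, so the account rests on the structures alone. The step is expected to be small, if any, tending toward a lower number rather than a higher one. Compound 4 is estimated in this assay at 600 nM, within a range from 200 nM to 1800 nM. That estimate corresponds to an expected step of a 1.4-fold lower number from compound 3 to compound 4 (0.16 log units; within the scatter).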

Compound 4, half-maximal inhibitory concentration: 74 nM
For compound 4 the middle estimate is 8.1-fold (0.91 log units) above the measured one; measured number outside the range, below it.
By their numbers in this assay, from the lowest: compounds 4 and 1 (each within the scatter of the next); then compound 2; then compound 3.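

On the shared core, 2-fluorobenzyl in place of phenyl gives a 12-fold lower number from compound 3 to compound 4 (1.07 log units; beyond the scatter) in this assay. The saturated ring carbon, three ring bonds from the ring nitrogen, is therefore not indifferent to what it carries, and a change there alone can move a weak member of this set to the low end of its numbers. Nothing available explains the gain. As far as these compounds go, the step changes two things at once, the carbon link and the fluorine, so their shares stay open. Plain benzyl and 2-fluorophenyl at this carbon would separate them.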